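The source may report more compounds than this note shows. Statements on the series, on what has been measured and on what is new or still open speak of the compounds shown alone.

Compound 1 `COc1cc(N2C(N)=C(C#N)C(c3ccc(OC)c4ccccc34)C3=C2CC(C)(C)CC3=O)cc(OC)c1OC` carries a 4-methoxynaphthalen-1-yl group on a saturated ring carbon, and in a functional assay on Ehrlich cells (Mus musculus) for cytotoxicity, tested at 25 ug/mL (on this read-out lower numbers stand for a weaker effect and higher numbers for a stronger effect at the one concentration tested), compound 1 gives 30%. Compound 2 `COc1cc(N2C(N)=C(C#N)C(c3cccs3)C3=C2CC(C)(C)CC3=O)cc(OC)c1OC` carries a thiophen-2-yl group there, and in this assay compound 2 gives 10%. Compound 3 `COc1cc(N2C(N)=C(C#N)C(c3c(OC)ccc4ccccc34)C3=C2CC(C)(C)CC3=O)cc(OC)c1OC` carries a 2-methoxynaphthalen-1-yl group, and in this assay compound 3 gives 5%, the lowest of the three numbers shown; its step from compound 1 is a number 25 percentage points lower from compound 1 to compound 3 (beyond the scatter), beyond the scatter, while the step of a number 5 percentage points lower from compound 2 to compound 3 (within the scatter) stays within the scatter.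

Compound 4 `COc1cc(N2C(N)=C(C#N)C(c3ccc(Cl)cc3Cl)C3=C2CC(C)(C)CC3=O)cc(OC)c1OC` has not yet been measured. 2,4-dichlorophenyl in place of 2-methoxynaphthalen-1-yl on a saturated ring carbon The measured steps that bear on this change all swap one aryl group for another on the same saturated ring carbon: a number 20 percentage points lower from compound 1 to compound 2 (beyond the scatter) and a number 25 percentage points lower from compound 1 to compound 3 (beyond the scatter) were modest, and a number 5 percentage points lower from compound 2 to compound 3 (within the scatter) was within the scatter. Among the measured compounds shown here, none of them brings in a dichlorophenyl group, so no matching step shows the direction for compound 4. The measured aryl swaps moved the number only modestly, and compound 4 is expected to show a step of a number 7 percentage points higher from compound 3 to compound 4 (within the scatter), at or near the scatter. Compound 4 is estimated at 12%, with a range from 0% to 30%.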

Compound 4, a percentage reported as activity, at one concentration (the size of the read-out at that concentration, not a potency): 55%
The estimate for compound 4 lay 43 percentage points below the measured number; the whole stated range lies below it.
By their numbers in this assay, from the lowest: compounds 3 and 2 (each within the scatter of the next); then compound 1; then compound 4.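

At this saturated ring carbon, the 2,4-dichlorophenyl group produces the largest changes yet seen in this assay, with a number 50 percentage points higher from compound 3 to compound 4 (beyond the scatter) and a number 45 percentage points higher from compound 2 to compound 4 (beyond the scatter), and even the best earlier aryl group falls short, with a number 25 percentage points higher from compound 1 to compound 4 (beyond the scatter). Compound 4 therefore stands highest of the four, with its steps to all the others beyond the scatter, which shows that this position can carry a much stronger effect than the thiophen-2-yl and methoxynaphthalenyl groups suggested, and that two six-membered aromatic rings of carbon are not required for it. Nothing measured here accounts for this gain.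

The compounds shown leave open whether both chlorine atoms and their placement matter, a question that a plain phenyl, a 4-chlorophenyl or a 2-chlorophenyl group at this carbon would address. They also leave open whether the gain holds across concentrations, as the read-out comes from a single concentration, and whether it persists when a different group replaces the 3,4,5-trimethoxyphenyl group elsewhere on the ring.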